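This account rests on a few compounds, and the source may have more. Where it says the series, first, only, none or still open, it means among the compounds named here.

Measured compounds in an assay on T47D cells for inhibition of Steryl-sulfatase (Homo sapiens), read by HPLC, with a stated time of 24 h; a lower number here means a stronger inhibitor, a higher number a weaker inhibitor:
Compound 1 `Cc1ccccc1N(C)C(=O)c1ccc(-c2ccc(OS(N)(=O)=O)cc2)o1` gives 28 nM.
Compound 2 `Cc1ccc(F)cc1N(C)C(=O)c1ccc(-c2ccc(OS(N)(=O)=O)cc2)o1` gives 40 nM.
Compound 3 `Cc1c(F)cccc1N(C)C(=O)c1ccc(-c2ccc(OS(N)(=O)=O)cc2)o1` gives 27 nM.

Compound 3 has the lowest of the three numbers, yet both its comparisons, a 1.0-fold lower number from compound 1 to compound 3 (0.02 log units; within the scatter) and a 1.5-fold lower number from compound 2 to compound 3 (0.17 log units; within the scatter), stay within the scatter, so the three compounds cannot be separated. Compound 4 `Cc1ccncc1N(C)C(=O)c1ccc(-c2ccc(OS(N)(=O)=O)cc2)o1` differs from compound 3 by 4-methylpyridin-3-yl in place of 3-fluoro-2-methylphenyl on an amide-type nitrogen. The measured steps, a 1.4-fold higher number from compound 1 to compound 2 (0.15 log units; within the scatter), a 1.0-fold lower number from compound 1 to compound 3 (0.02 log units; within the scatter) and a 1.5-fold lower number from compound 2 to compound 3 (0.17 log units; within the scatter), concern only fluoro in place of hydrogen on the aryl group at the amide nitrogen; none exchanges the carbon-only ring for a ring with a hetero atom. Those steps show that small changes on this group left this assay unmoved, but the new change is of a different kind. Compound 4 is therefore expected to show a 1.5-fold higher number from compound 3 to compound 4 (0.17 log units; within the scatter), no more than a modest shift. The estimate for compound 4 is 40 nM, within 12 nM to 130 nM.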

Compound 4, half-maximal inhibitory concentration: 820 nM
The estimate for compound 4 lay 21-fold (1.31 log units) below the measured number, outside the stated range (above it).
By their numbers in this assay, from the lowest: compounds 3, 1 and 2 (each within the scatter of the next); then compound 4.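

Exchanging the carbon-only ring on the amide-type nitrogen for 4-methylpyridin-3-yl has a large effect in this assay (a 30-fold higher number from compound 3 to compound 4 (1.48 log units; beyond the scatter)), (a 21-fold higher number from compound 2 to compound 4 (1.31 log units; beyond the scatter)) and (a 29-fold higher number from compound 1 to compound 4 (1.47 log units; beyond the scatter)). Thus, this position, unmoved by fluoro in place of hydrogen, does respond to a ring with a hetero atom. Nothing available explains this loss.

On these data alone, it remains open whether other rings with hetero atoms, such as a pyrimidine, would bring the same loss. Also open, as far as these compounds go, is how a methoxy group or an amine on the carbon-only ring would compare.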